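Cyclohexyl in place of heptyl: an expected growth-inhibition value

This account rests on a few compounds, and the source may have more. Where it says the series, first, only, none or still open, it means among the compounds named here.

Compound 1: `Cc1ccc(S(=O)(=O)N2CCC(Cl)=CC2CC(C)C)cc1`, 31000 nM
Compound 2: `CCCCCCCC1C=C(Cl)CCN1S(=O)(=O)c1ccc(C)cc1`, 49000 nM

In a functional assay on SW1573 cells (Homo sapiens) for antiproliferative activity, read by sulforhodamine B assay, with a stated time of 48 h (on this read-out higher numbers stand for weaker inhibition of growth and lower numbers for stronger inhibition of growth), compound 1 gives 31000 nM. In this assay compound 2 gives 49000 nM. Going by the values given here, compound 2 sits alongside compound 1 on these two numbers: the only measured step, a 1.6-fold higher number from compound 1 to compound 2 (0.20 log units; within the scatter), lies within the scatter, so the two cannot be told apart.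

Compound 3 is `Cc1ccc(S(=O)(=O)N2CCC(Cl)=CC2C2CCCCC2)cc1`. It differs from compound 2 by cyclohexyl in place of heptyl on a saturated ring carbon. Among the compounds with values here, the one step that bears on this change is a 1.6-fold higher number from compound 1 to compound 2 (0.20 log units; within the scatter), which also altered the group on that saturated ring carbon and stayed within the scatter. Within the data shown here, no measured pair exchanges a chain for a ring at this position, so the expectation rests on that single step alone. Compound 3 is therefore expected to show no step beyond the scatter, a 1.2-fold lower number from compound 2 to compound 3 (0.09 log units; within the scatter), in this assay. The estimate for compound 3 in this assay is 40000 nM, with a range from 15000 nM to 110000 nM.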

Compound 3, concentration for 50% growth inhibition: 62000 nM
Compound 3: middle estimate off by 1.6-fold (0.19 log units), on the low side; the range from low to high includes it.
By their numbers in this assay, from the lowest: compounds 1, 2 and 3 (each within the scatter of the next).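

Going by these compounds alone, with compound 3, a ring stands for the first time on the saturated ring carbon next to the ring nitrogen, and in this assay the exchange of heptyl for cyclohexyl gives a 1.3-fold higher number from compound 2 to compound 3 (0.10 log units; within the scatter). The exchange of isobutyl for cyclohexyl gives a 2.0-fold higher number from compound 1 to compound 3 (0.30 log units; within the scatter), so on these numbers cyclohexyl cannot be told apart from either chain, and the earlier chain-for-chain step gains a chain-for-ring counterpart that also stays within the scatter. Nothing given here accounts for this lack of separation among the three compounds.

Going by these compounds, whether any group at this place can move the number beyond the scatter stays open, since the three compounds carry only carbon groups without hydrogen-bond donors or acceptors, and an amine, a carboxylic acid or a phenyl ring on that saturated ring carbon could answer this. On these data alone, it also stays open whether a group as small as methyl at the same place would give a number that can be told apart from those of compound 1, compound 2 and compound 3.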